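Trimming the Side Chain to a Carbamoyl Group

This account rests on a few compounds, and the source may have more. Where it says the series, first, only, none or still open, it means among the compounds named here.

Measured so far in a physicochemical assay for lipophilicity, read by HPLC, measured as octanol-water partition; a higher number here means a more lipophilic compound, a lower number a more polar compound:
compound 1, `COC[C@H]1CN(c2ccc(-n3cc(-c4ccccn4)cn3)c(F)c2)C(=O)O1`: 2.18
compound 2, `O=C1O[C@@H](CSc2cccs2)CN1c1ccc(-n2cc(-c3ccccn3)cn2)c(F)c1`: 4.29
compound 3, `O=C(NC[C@H]1CN(c2ccc(-n3cc(-c4ccccn4)cn3)c(F)c2)C(=O)O1)C(F)F`: 1.9

Compound 3 stands lowest of the three numbers in this assay. Its nearest neighbour is compound 1, and the step of a number 0.28 log units lower from compound 1 to compound 3 (within the scatter) lies within the scatter, so the two cannot be ordered. The step of a number 2.39 log units lower from compound 2 to compound 3 (beyond the scatter) is large, and it is matched by the large step of a number 2.11 log units higher from compound 1 to compound 2 (beyond the scatter) in the other direction.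

Compound 4, `NC(=O)[C@H]1CN(c2ccc(-n3cc(-c4ccccn4)cn3)c(F)c2)C(=O)O1`, has not yet been measured. It differs from compound 3 in one place: carbamoyl in place of (((difluoromethyl)carbonyl)amino)methyl on a saturated ring carbon. The measured steps that bear on this change are the two that vary the same ring position, a number 0.28 log units lower from compound 1 to compound 3 (within the scatter) and a number 2.39 log units lower from compound 2 to compound 3 (beyond the scatter); neither of them introduces a carbamoyl group, so they guide only loosely. The group that leaves carries two fluorine atoms and three carbon atoms, while the carbamoyl that enters is smaller, so a step downward in this assay is expected for compound 4, of moderate size, a number 0.70 log units lower from compound 3 to compound 4 (beyond the scatter). The estimate for compound 4 in this assay is 1.2, with a range from 0.6 to 1.8.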

Compound 4, partition coefficient: 1.59
The estimate for compound 4 lay 0.39 log units below the measured number; the range from low to high includes it.
By their numbers in this assay, from the lowest: compound 4; then compounds 3 and 1 (each within the scatter of the next); then compound 2.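

In this assay, going by these compounds alone, the carbamoyl group on this saturated ring carbon gives the first change at the position that separates from the methoxymethyl of the parent series: a number 0.59 log units lower from compound 1 to compound 4 (beyond the scatter), modest but clear, where the difluoroacetamide side chain of compound 3 could not be ordered against compound 1. The step of a number 0.31 log units lower from compound 3 to compound 4 (beyond the scatter) is also modest, although it removes both fluorine atoms and leaves the counts of hydrogen-bond donors and acceptors unchanged, while a number 2.70 log units lower from compound 2 to compound 4 (beyond the scatter) is large and makes compound 4 the lowest of the four compounds, beyond the scatter of each of the others. No measurement at hand explains the size of any of these steps.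

The compounds shown leave open whether these steps belong to the carbamoyl group itself or to the loss of the saturated chain carbon that the other three compounds carry at this ring carbon, a question that a carbamoylmethyl group would address. They also leave open how a carboxylic acid, a primary amine or a longer chain ending in an amide would read at the same position.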